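The source may report more compounds than this note shows. Statements on the series, on what has been measured and on what is new or still open speak of the compounds shown alone.

Compound 2 `COc1cc(-c2nnc3n2NC(c2ccco2)C(C(=O)c2cccc(Br)c2)S3)cc(OC)c1OC` carries the shared core with a 3-bromophenyl on the carbonyl carbon. In a functional assay on A549 cells (Homo sapiens) for cytotoxicity, read by MTT assay, with a stated time of 48 h (on this read-out higher numbers stand for weaker inhibition and lower numbers for stronger inhibition), compound 2 gives 36900 nM. Compound 1 `COc1cc(-c2nnc3n2NC(c2ccco2)C(C(=O)c2ccc(Br)cc2)S3)cc(OC)c1OC` carries a 4-bromophenyl instead; in this assay compound 1 gives 42100 nM, and the step of a 1.1-fold lower number from compound 1 to compound 2 (0.06 log units; within the scatter) stays within the scatter. Compound 3 `COc1cccc(C(=O)C2Sc3nnc(-c4cc(OC)c(OC)c(OC)c4)n3NC2c2ccco2)c1` brings a different change, (methoxy in place of bromo on an aromatic carbon). No measured step involves this swap, so nothing shown points in either direction. The expected step of a 1.0-fold higher number from compound 2 to compound 3 (0.00 log units; within the scatter) is therefore no change beyond the scatter, and compound 3 is estimated to give 37000 nM, with a range from 15000 nM to 90000 nM.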

Compound 3, half-maximal inhibitory concentration: > 100000 nM
Compound 3 gave a limit, no number (the forecaster's own chance of this, stated with the estimate: 10%); middle value at least 2.7-fold (0.43 log units) away from the limit.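

Swapping 3-bromophenyl for 4-bromophenyl had stayed within the scatter, so the earlier compounds gave no sign that this group could matter; replacing the bromo itself shows that it can. In this assay, methoxy in place of bromo gives an at least 2.7-fold higher number from compound 2 to compound 3 (0.43 log units; beyond the scatter), and the comparison with the 4-bromophenyl compound gives an at least 2.3-fold higher number from compound 1 to compound 3 (0.37 log units; beyond the scatter), both pointing to weaker inhibition. Compound 3 gives a limit of the assay, not a number: the limit of > 100000 nM in this assay, at which 1 of the 3 values shown sits.

On these data alone, how far compound 3 lies past that limit remains open. So does whether chloro or an amine on this aromatic carbon would keep the inhibition seen with bromo.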